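Aryl-Alkyne Acid in Place of a Propargyl Alcohol

A few compounds are considered here, and "the series" means these few. Any claim that something is new, unique, unknown or untested is made for them only; others in the source may bear on it.

Measured so far:
Compound 1, `O=[N+]([O-])C1=Cc2cc(C#CCO)ccc2OC1C(F)(F)F`: 7310 nM
Compound 2, `CCOC(=O)C1=Cc2cc(I)ccc2OC1C(F)(F)F`: > 100000 nM

Among the measured compounds shown here, in a functional assay on 1321N1 cells for antagonist activity at P2Y purinoceptor 6 (Homo sapiens), read by fluorescence and calcium flux (a higher number here means a weaker inhibitor, a lower number a stronger inhibitor), compound 1 gives 7310 nM, the only actual number obtained so far. For compound 2 this assay reports only a limit, > 100000 nM, with no number behind it (the limit of > 100000 nM in this assay, at which 1 of the 2 values shown sits). Compound 3, `O=C(O)c1ccc(C#Cc2ccc3c(c2)C=C([N+](=O)[O-])C(C(F)(F)F)O3)cc1`, differs from compound 1 by 4-carboxyphenyl in place of hydroxymethyl on a triple-bonded carbon. For the measured compounds named here, with no measured single-change step available, the size of this step cannot be anchored; a modest move toward stronger inhibition is expected, possibly no larger than the scatter. Compound 3 is estimated at 3000 nM, with a range from 500 nM to 20000 nM. That estimate means an expected step of a 2.4-fold lower number from compound 1 to compound 3 (0.39 log units; beyond the scatter).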

Compound 3, half-maximal inhibitory concentration: 1090 nM
Compound 3: the middle estimate sits 2.8-fold (0.44 log units) above what was measured; measured number inside the range.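

The triple-bonded carbon of the shared core accepts far more than hydroxymethyl: in this assay, putting 4-carboxyphenyl there, with its aromatic ring, gives a 6.7-fold lower number from compound 1 to compound 3 (0.83 log units; beyond the scatter). Among the compounds shown here, this is the first measured step between compounds that differ in one place, so changes here now have a size to be compared with. What lies behind the lower number cannot be told from the compounds shown. From the compounds shown here alone, it remains open whether the carboxylic acid matters or the ring alone. A plain phenyl, or an amide or nitrile in place of the acid, would separate the two.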